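Chloro for methoxy on the pendant phenyl of compound 3

The source may report more compounds than this note shows. Statements on the series, on what has been measured and on what is new or still open speak of the compounds shown alone.

Measured so far in an ADME assay on Vero cells (Chlorocebus sabaeus) for cytotoxicity, read by fluorescence and resazurin assay, with a stated time of 72 h; a higher number here means that more compound is tolerated, a lower number that less compound is tolerated:
compound 1 `CC1=CSC2=NC(/C=C/c3ccccc3)=C(C(=O)/C=C/c3ccccc3)C(c3ccccc3)N12`: 195 ug/mL
compound 2 `CC1=CSC2=NC(/C=C/c3ccc(Br)cc3)=C(C(=O)/C=C/c3ccc(Br)cc3)C(c3ccccc3)N12`: 282 ug/mL
compound 3 `COc1ccc(C2C(C(=O)/C=C/c3ccccc3)=C(/C=C/c3ccccc3)N=C3SC=C(C)N32)cc1`: 211 ug/mL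

The three numbers lie close together. Compound 3 sits between the other two, all within the scatter of one another: its nearest neighbour is compound 1, its furthest compound 2, and neither gap exceeds the scatter. Going by the values given here, the one single-point step so far, a 1.1-fold higher number from compound 1 to compound 3 (0.03 log units; within the scatter), is within the scatter.

Compound 4 `CC1=CSC2=NC(/C=C/c3ccccc3)=C(C(=O)/C=C/c3ccccc3)C(c3ccc(Cl)cc3)N12` differs from compound 3 by chloro in place of methoxy on an aromatic carbon. Among the compounds with values here, no measured pair makes exactly this exchange, so the expectation rests on what the set shows: the methoxy step from compound 1 to compound 3 stayed within the scatter, and compound 2, which carries bromo on two other rings, also lies within the scatter of compound 1 and compound 3. Halogen and methoxy substitution have so far left this assay unmoved. The step of a 1.0-fold higher number from compound 3 to compound 4 (0.02 log units; within the scatter) is therefore expected to stay within the scatter. Compound 4 is estimated at 220 ug/mL, with a range from 130 ug/mL to 380 ug/mL.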

Compound 4, half-maximal cytotoxic concentration: 320 ug/mL
Compound 4: middle estimate off by 1.5-fold (0.16 log units), on the low side; low and high end bracket the measured number.
By their numbers in this assay, from the lowest: compounds 1, 3, 2 and 4 (each within the scatter of the next).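

In this assay, the change from 4-methoxyphenyl to 4-chlorophenyl gives a 1.5-fold higher number from compound 3 to compound 4 (0.18 log units; within the scatter), and chloro in place of hydrogen at the same place gives a 1.6-fold higher number from compound 1 to compound 4 (0.22 log units; within the scatter). Earlier compounds had shown only methoxy at this place, with bromo confined to other rings; with a halogen now on this ring too, hydrogen, methoxy and chloro on this aromatic carbon, para to a large group, cannot be told apart by this measure. No measurement shown here bears on a cause for these numbers.

The compounds shown leave open whether an amine or a carboxylic acid at this place would also stay within the scatter. They also leave open whether a longer chain, such as butoxy in place of methoxy, would do so.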